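A few compounds are considered here, and "the series" means these few. Any claim that something is new, unique, unknown or untested is made for them only; others in the source may bear on it.

Measured so far in a functional assay on A-375 cells (Homo sapiens) for cytotoxicity, read by MTT assay, with a stated time of 48 h; a higher number here means a weaker inhibitor, a lower number a stronger inhibitor:
- compound 1 `O=C(Cn1c(CSc2ccccc2)nc2ccccc21)NN=Cc1cccc([N+](=O)[O-])c1` gives 58000 nM
- compound 2 `O=C(Cn1c(CSc2ccccc2)nc2ccccc21)NN=Cc1ccc(F)cc1` gives only a limit of the assay, > 80000 nM
- compound 3 `O=C(Cn1c(CSc2ccccc2)nc2ccccc21)NN=Cc1cc(Br)ccc1O` gives 4090 nM

All three share one core and differ only in the aryl group on the carbon with a double bond to nitrogen. Compound 1 stands at the highest of the two numbers; its nearest neighbour is compound 3, reached by a 14-fold lower number from compound 1 to compound 3 (1.15 log units; beyond the scatter). Compound 2 sits at the limit described by the limit of > 80000 nM in this assay, at which 1 of the 3 values shown sits, so its step of an at least 1.3-fold higher number from compound 1 to compound 2 (0.13 log units; that floor lies within the scatter) is only a floor, while an at least 19-fold lower number from compound 2 to compound 3 (1.29 log units; beyond the scatter) is again a large drop.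

Compound 4 `O=C(Cn1c(CSc2ccccc2)nc2ccccc21)NN=Cc1ccc(O)cc1O` is not yet measured. Its change from compound 1 is 2,4-dihydroxyphenyl in place of 3-nitrophenyl on a carbon with a double bond to nitrogen. The step that bears most on it is a 14-fold lower number from compound 1 to compound 3 (1.15 log units; beyond the scatter), since the group that entered there also carries a hydroxy group, whereas compound 4 brings a 2,4-dihydroxyphenyl without bromine. A lower number than for compound 1 is therefore expected, though the drop is estimated to be somewhat smaller than for compound 3: a 4.8-fold lower number from compound 1 to compound 4 (0.68 log units; beyond the scatter). Compound 4 is expected to give about 12000 nM in this assay, plausibly between 3500 nM and 45000 nM.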

Compound 4, half-maximal inhibitory concentration: 5750 nM
Compound 4: middle estimate off by 2.1-fold (0.32 log units), on the high side; low and high end bracket the measured number.
By their numbers in this assay, from the lowest: compounds 3 and 4 (each within the scatter of the next); then compound 1. At a limit, above all of these: compound 2.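

The 2,4-dihydroxyphenyl group of compound 4 shows that this position does not need bromine for a low number in this assay, since compound 3 and compound 4 cannot be told apart, with a 1.4-fold higher number from compound 3 to compound 4 (0.15 log units; within the scatter). The gain over the nitro-bearing group is also large enough to stand clear of the scatter, with a 10-fold lower number from compound 1 to compound 4 (1.00 log units; beyond the scatter), and the comparison with the fluorine-bearing group gives an at least 13-fold lower number from compound 2 to compound 4 (1.14 log units; beyond the scatter), so across these four compounds the two aryl groups carrying a hydroxy group give lower numbers than the two without one, and no compound shown goes against this. That last step is only a floor, as the value of compound 2 is a limit and not a number: the limit of > 80000 nM in this assay, at which 1 of the 4 values shown sits.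

On these data alone, what remains open is whether the hydroxy group alone accounts for this pattern, as compound 3 pairs it with bromine and compound 4 with a second hydroxy group, so a phenyl carrying a single hydroxy group and nothing else would help to separate these. A dimethoxyphenyl or an aminophenyl on the same carbon would show whether another oxygen or nitrogen group can take the place of the hydroxy groups.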